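A few compounds are considered here, and "the series" means these few. Any claim that something is new, unique, unknown or untested is made for them only; others in the source may bear on it.

Series notes. Compound 2 `CN(C)CC(=O)N1CCC[C@H]1C(=O)N1CCC(NS(=O)(=O)c2cc(S(=O)(=O)c3ccccc3)ccc2C(F)(F)F)CC1` gives 310 nM in a functional assay on U2OS cells for antagonist activity at proto-oncogene Wnt-3 (Homo sapiens), read by a luciferase reporter, with a stated time of 18 h (on this read-out lower numbers stand for an effect already at smaller amounts and higher numbers for an effect only at larger amounts of compound), and sits as the higher of the two numbers obtained so far; the nearest is compound 1 `CC(C)(C)OC(=O)N1CCC[C@@H]1C(=O)N1CCC(NS(=O)(=O)c2cc(S(=O)(=O)c3ccccc3)ccc2C(F)(F)F)CC1`, which in this assay gives 210 nM, and the two lie within the scatter of each other. For the measured compounds named here, the only step measured to date, a 1.5-fold higher number from compound 1 to compound 2 (0.17 log units; within the scatter), exchanged the carbamate cap on the pyrrolidine nitrogen for an aminoacyl cap without moving the number beyond the scatter.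

Compound 3 `CC(C)(C)NC(=O)N1CCC[C@H]1C(=O)N1CCC(NS(=O)(=O)c2cc(S(=O)(=O)c3ccccc3)ccc2C(F)(F)F)CC1` is not yet measured. It differs from compound 2 by (tert-butyl)amino in place of (dimethylamino)methyl on a carbonyl carbon. This is again a change at the same cap on the shared core, now to a urea. Going by the values given here, the one step that bears on it, from compound 1 to compound 2, was small, so the cap appears tolerant across the two variants seen; no step beyond the scatter is expected here either, in either direction.

The number for compound 3 in this assay is therefore estimated at 250 nM, with a range of 100 nM to 650 nM. This estimate means a step of a 1.2-fold lower number from compound 2 to compound 3 (0.09 log units; within the scatter), which is expected to stay within the scatter.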

Compound 3, half-maximal effective concentration: 30 nM
The estimate for compound 3 lay 8.3-fold (0.92 log units) above the measured number; measured number below the stated range.
By their numbers in this assay, from the lowest: compound 3; then compounds 1 and 2 (each within the scatter of the next).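

In this assay, for the compounds shown here, the group on this carbonyl carbon turns out to matter: (tert-butyl)amino in place of (dimethylamino)methyl gives a 10-fold lower number from compound 2 to compound 3 (1.01 log units; beyond the scatter), the first step to lie clearly beyond the scatter. The (tert-butyl)carbamoyl cap also stands apart from the tert-butoxycarbonyl cap, with a 7.0-fold lower number from compound 1 to compound 3 (0.85 log units; beyond the scatter), so the flat picture left by compound 1 and compound 2 held only for those two caps, and the urea is the one variant of the three that separates from the others. No measurement at hand accounts for this gain.

The change from compound 2 to compound 3 alters more than one feature at once, since the entering group carries a hydrogen-bond donor and a tert-butyl where the leaving group has neither, so the compounds shown do not say which of these goes with the lower number. A (tert-butyl)(methyl)amino group and a smaller methylamino group on the same carbonyl carbon would pull these two features apart, and a cyclohexylamino group would show how much larger this substituent can be.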